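Moving the chloro group: from compound 3 to compound 4

The source may hold more compounds than are shown below. What is called first, only, known or untested is meant among the compounds shown, and "the series" means these compounds.

Of the compounds shown here, three sharing one core have been measured in an assay on isolated protein for inhibition of protein kinase C iota type (Homo sapiens), tested at 20 uM; on this read-out lower numbers stand for less inhibition and higher numbers for more inhibition at the one concentration tested (going by the name of the read-out). Compound 1 `CC(C)(C)C1=NN(c2cccc(Cl)c2)C(c2ccc(O)cc2)C1` gives 43.5%, compound 2 `Cc1cccc(N2N=C(C(C)(C)C)CC2c2ccc(O)cc2)c1` gives 13.9%, and compound 3 `Oc1ccc(C2CC(c3ccccc3)=NN2c2ccc(Cl)cc2)cc1` gives 31.6%. Compound 3 thus stands second highest of the three: compound 1 lies higher by a margin beyond the scatter, and compound 2 lies lower by a margin beyond the scatter. For the measured compounds named here, the only single-point step recorded so far is a number 29.6 percentage points lower from compound 1 to compound 2 (beyond the scatter), a change that does not touch the chlorine itself.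

Compound 4 `Oc1ccc(C2CC(c3ccccc3)=NN2c2cccc(Cl)c2)cc1` is the next compound to be tested in this assay. It differs from compound 3 in one respect: 3-chlorophenyl in place of 4-chlorophenyl on an amine nitrogen in a ring. Going by the values given here, no measured pair records this very change, so the step from compound 1 to compound 2 only shows that altering this aryl group can shift the read-out modestly. Compound 1, which also carries a 3-chlorophenyl group, shows a value somewhat higher than compound 3, though its other substituent differs. Compound 4 is therefore expected to land near compound 3 or slightly above, at 40% with a range of 20% to 60%, which means an expected step of a number 8.4 percentage points higher from compound 3 to compound 4 (within the scatter).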

Compound 4, a percentage reported as inhibition, at one concentration (the size of the read-out at that concentration, not a potency): 45.5%
For compound 4 the middle estimate is 5.5 percentage points below the measured one, within the range that was stated.
By their numbers in this assay, from the lowest: compound 2; then compound 3; then compounds 1 and 4 (each within the scatter of the next).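

In this assay the move of the chlorine gives a number 13.9 percentage points higher from compound 3 to compound 4 (beyond the scatter) and thereby shows that, with the same atoms present, 3-chlorophenyl and 4-chlorophenyl on the amine nitrogen in the ring can be told apart. With 3-chlorophenyl held constant, phenyl in place of tert-butyl gives a number 2 percentage points higher from compound 1 to compound 4 (within the scatter) and so leaves these two groups on the carbon with a double bond to nitrogen indistinguishable in this read-out. No evidence bears on why the place of the chlorine matters here.

From the compounds shown here alone, it remains open whether an amine or a carboxylic acid on this aryl ring would keep the read-out at the level of the 3-chlorophenyl compounds. The role of the 4-hydroxyphenyl group is also unsettled, since it stays the same throughout.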